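Hydroxy for methoxy on the chlorophenyl ring: compound 4

The source may hold more compounds than are shown below. What is called first, only, known or untested is meant among the compounds shown, and "the series" means these compounds.

Three members of the series carry a number or a limit in a functional assay on HT-29 cells (Homo sapiens) for inhibition, read by sulforhodamine B assay, with a stated time of 48 h; on this read-out higher numbers stand for lower toxicity in this test and lower numbers for higher toxicity in this test. Compound 1 `O=C(Nc1cccc(-n2cc(-c3ccncc3)c(-c3ccc(Cl)c(O)c3)n2)c1)Nc1cccc(C(F)(F)F)c1` gives > 32500 nM, which is a limit of the measurement and not a number. Going by the values given here, compound 2 `COc1cc(-c2nn(-c3cccc(NC(=O)Nc4cc(C(F)(F)F)cc(C(F)(F)F)c4)c3)cc2-c2ccncc2)ccc1Cl` gives 3710 nM, and compound 3 `COc1cc(-c2nn(-c3cccc(NC(=O)Nc4cccc(C(F)(F)F)c4)c3)cc2-c2ccncc2)ccc1Cl` gives 4670 nM; these are the only two numbers, and the step of a 1.3-fold higher number from compound 2 to compound 3 (0.10 log units; within the scatter) lies within the scatter, so neither stands apart from the other. Among the compounds with values here, compound 1 differs from compound 3 in one place, and that step, an at least 6.9-fold lower number from compound 1 to compound 3 (0.84 log units; beyond the scatter), is the one that concerns the change considered here, with the limit of > 32500 nM in this assay, at which 1 of the 3 values shown sits, setting its floor.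

Compound 4 `O=C(Nc1cccc(-n2cc(-c3ccncc3)c(-c3ccc(Cl)c(O)c3)n2)c1)Nc1cc(C(F)(F)F)cc(C(F)(F)F)c1` is not yet measured. It differs from compound 2 by hydrogen in place of methyl on an oxygen on an aromatic ring. This is the reverse of the change from compound 1 to compound 3, so the expectation is a step towards higher numbers in this assay of about the size seen there or larger, since the step from compound 1 to compound 3 was itself bounded by the limit of the measurement.

On that basis the step from compound 2 to compound 4 is expected to be an 8.1-fold higher number from compound 2 to compound 4 (0.91 log units; beyond the scatter). Compound 4 is therefore estimated at 30000 nM, with a range from 12000 nM to 100000 nM, and a real chance that only a limit is reported.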

Compound 4, concentration lethal to 50% of the cells: 4670 nM
Beside the measured number, compound 4's estimate is 6.4-fold (0.81 log units) above it; measured number below the stated range.
By their numbers in this assay, from the lowest: compounds 2, 3 and 4 (each within the scatter of the next). At a limit, above all of these: compound 1.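

In this assay the change from methoxy to hydroxy on the 4-chloro-3-methoxyphenyl ring does not carry a single size across the series: a 1.3-fold higher number from compound 2 to compound 4 (0.10 log units; within the scatter), so the large step seen on the core of compound 1 does not transfer to the core of compound 2: the same change on two cores in this assay, an at least 6.9-fold lower number (0.84 log units; beyond the scatter) from compound 1 to compound 3 and a 1.3-fold lower number (0.10 log units; within the scatter) from compound 4 to compound 2, at least 5.5-fold (0.74 log units) apart, beyond the scatter of two such steps The trifluoromethyl change is likewise tied to its partner on the oxygen, with an at least 6.9-fold lower number from compound 1 to compound 4 (0.84 log units; beyond the scatter) on the hydroxy pair, while the methoxy pair shows no step beyond the scatter: the same change on two cores in this assay, a 1.3-fold higher number (0.10 log units; within the scatter) from compound 2 to compound 3 and an at least 6.9-fold higher number (0.84 log units; beyond the scatter) from compound 4 to compound 1, at least 5.5-fold (0.74 log units) apart, beyond the scatter of two such steps The value of compound 1 is a limit and not a number: the limit of > 32500 nM in this assay, at which 1 of the 4 values shown sits.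

Open, going by these compounds, is whether the separation belongs to the particular combination in compound 1 or to a wider set of hydroxy compounds, as compound 1 alone stands apart from compound 2, compound 3 and compound 4. An ethyl group on the same oxygen, or an amine in place of the hydroxy on the 4-chloro-3-hydroxyphenyl ring, would test how far this dependence on the rest of the molecule extends.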